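Adding a hydroxy to the aryl group of compound 2

The source may hold more compounds than are shown below. What is called first, only, known or untested is meant among the compounds shown, and "the series" means these compounds.

Compound 2 `Cc1ccccc1N1CCN(CCCNc2ncccc2C(=O)N(C)C)CC1` carries a 2-methylphenyl on the ring nitrogen of the shared core. In a functional assay on aorta for antagonist activity at Alpha-1D adrenergic receptor (Rattus norvegicus) (on this read-out higher numbers stand for weaker binding and lower numbers for tighter binding), compound 2 gives 10 nM. Within the data shown here, its one measured neighbour is compound 1 `COc1ccccc1N1CCN(CCCNc2ncccc2C(=O)N(C)C)CC1`, which in this assay gives 20 nM; the two numbers lie within the scatter of each other, the step being a 2.0-fold lower number from compound 1 to compound 2 (0.30 log units; within the scatter). Compound 3 `COc1cc(O)ccc1N1CCN(CCCNc2ncccc2C(=O)N(C)C)CC1` has not yet been measured. Its change from compound 2 is 4-hydroxy-2-methoxyphenyl in place of 2-methylphenyl on an amine nitrogen in a ring. Among the measured compounds shown here, the only measured step that bears on this change is the one from compound 1 to compound 2, which exchanged methyl and methoxy on the same aromatic ring and stayed within the scatter; the hydroxy that also enters has no counterpart among the measured compounds, so its contribution is unknown. Since the methoxy returns, compound 3 is expected to sit near the value of compound 1, with wide uncertainty from the hydroxy. The step expected for compound 3 is a 2.5-fold higher number from compound 2 to compound 3 (0.40 log units; beyond the scatter). The estimate for compound 3 in this assay is 25 nM, in a range from 6 nM to 100 nM.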

Compound 3, dissociation constant: 79.4 nM
Compound 3: middle estimate off by 3.2-fold (0.50 log units), on the low side; measured number inside the range.
By their numbers in this assay, from the lowest: compounds 2 and 1 (each within the scatter of the next); then compound 3.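

Placing a hydroxy on the aryl group of compound 1 gives a 4.0-fold higher number from compound 1 to compound 3 (0.60 log units; beyond the scatter) in this assay, so this aryl group on the amine nitrogen in a ring does respond to substitution, whereas the exchange of methyl and methoxy had stayed within the scatter. The full change from 2-methylphenyl to 4-hydroxy-2-methoxyphenyl amounts to a 7.9-fold higher number from compound 2 to compound 3 (0.90 log units; beyond the scatter), and the hydroxy alone, measured against compound 1 with the methoxy held in place, is already enough to carry a step beyond the scatter toward weaker binding. No measurement here gives a reason for this loss.

With a hydroxy as the only group shown at this carbon, it remains open whether an amine, a fluorine or a second methoxy there would give a step of similar size. From the compounds shown here alone, it is equally open whether a hydroxy on the 2-methylphenyl of compound 2 would have the same effect as it has alongside the methoxy, and whether a hydroxy at another carbon of this aryl ring would be tolerated any better.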